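Swapping chloro for trifluoromethyl on a compound at a limit

A few compounds are considered here, and "the series" means these few. Any claim that something is new, unique, unknown or untested is made for them only; others in the source may bear on it.

Of the compounds shown here, three sharing one core have been measured in a physicochemical assay for solubility, measured as kinetic solubility; a lower number here means a less soluble compound, a higher number a more soluble compound. Compound 1 `CNC(=O)c1cc(C(=O)N[C@H]2CC[C@H](O)CC2)n([C@@H](C)c2ccc(Cl)cc2)n1` gives >= 132 ug/mL, which is a limit and not a number. Compound 2 `CNC(=O)c1cc(C(=O)N[C@H]2CC[C@H](O)CC2)n([C@@H](C)c2cccc(Cl)c2)n1` gives >= 143 ug/mL, again only a limit. Compound 3 `CNC(=O)c1cc(C(=O)N[C@H]2[C@@H]3C[C@H](O)C[C@@H]32)n([C@@H](C)c2cccc(Cl)c2)n1` gives >= 168 ug/mL, also a limit. Compound 2 therefore has no exact value, and neither do the two compounds around it.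

Compound 4 `CNC(=O)c1cc(C(=O)N[C@H]2CC[C@H](O)CC2)n([C@@H](C)c2cccc(C(F)(F)F)c2)n1` has not yet been measured. It differs from compound 2 in one place: trifluoromethyl in place of chloro on an aromatic carbon. In words, trifluoromethyl stands in place of chloro on an aromatic carbon.

Within the data shown here, two measured steps bear on this change. Among the measured compounds shown here, the first is a step that the two limits leave unreadable from compound 1 to compound 2, where 3-chlorophenyl replaces 4-chlorophenyl. The second is a step that the two limits leave unreadable from compound 2 to compound 3, a change of group on an amide-type nitrogen. Neither has a readable size, and neither swaps chloro for trifluoromethyl, so they set no direction. A step beyond the scatter in this assay is therefore not expected, and compound 4 may well return a limit too. The estimate amounts to an expected at least 1.1-fold lower number from compound 2 to compound 4 (0.04 log units; that floor lies within the scatter). Compound 4 is expected at 130 ug/mL, with an estimated range from 60 ug/mL to 180 ug/mL.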

Compound 4, solubility: 7 ug/mL
Compound 4: middle estimate off by 19-fold (1.27 log units), on the high side; the whole stated range lies above it.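

Placing trifluoromethyl where chloro stood, on an aromatic carbon meta to a large group, gives in this assay an at least 20-fold lower number from compound 2 to compound 4 (1.31 log units; beyond the scatter), so at this position the two groups cannot be treated as interchangeable, even though neither carries a hydrogen-bond donor or acceptor or a net charge. Among these compounds, compound 4 also supplies the first exact number in this set, and the comparison with the 4-chlorophenyl compound points the same way, with an at least 18-fold lower number from compound 1 to compound 4 (1.27 log units; beyond the scatter). Compound 2 carries only a limit, so the step from it gives a floor and not a full size: the limit of >= 143 ug/mL in this assay, at which 1 of the 4 values shown sits.

The steps among compounds 1, 2 and 3 cannot be read, so these compounds do not show how much the chloro position or the group on the amide nitrogen matters, and nothing here explains why the trifluoromethyl swap has so large a step. On these data alone, it also stays open whether a smaller group at the same aromatic carbon, such as methyl or a nitrile, would keep the read-out near the chloro compounds, and whether trifluoromethyl would give a similar step on the amide group of compound 3.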